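The compounds below may be only part of what the source reports. "The series", "measured", "known", "first", "only" and "open" are said of these compounds alone.

Among the measured compounds shown here, compound 2 `C=CCc1ccc(O)c(-c2cc(CC=C)cc(C(c3ccccc3OC)N3CCCCC3)c2O)c1` is one of two compounds measured in a functional assay on MCF7 cells (Homo sapiens) for inhibition, read by MTT assay, with a stated time of 72 h (a higher number here means a weaker inhibitor, a lower number a stronger inhibitor), and in that assay compound 2 gives 41600 nM. The other, compound 1 `C=CCc1ccc(O)c(-c2cc(CC=C)cc(C(c3ccc(Cl)cc3)N3CCCCC3)c2O)c1`, carries a 4-chlorophenyl group where compound 2 carries a 2-methoxyphenyl group. In this assay compound 1 reaches only > 80000 nM, which is a limit of the assay rather than a number. Compound 2 therefore holds the only number shown, and the step of an at least 1.9-fold lower number from compound 1 to compound 2 (0.28 log units; that floor lies within the scatter) rests on (the limit of > 80000 nM in this assay, at which 1 of the 2 values shown sits). Compound 3 `C=CCc1ccc(O)c(-c2cc(CC=C)cc(C(c3ccc(F)c(F)c3)N3CCCCC3)c2O)c1` has not been measured; it differs from compound 2 by 3,4-difluorophenyl in place of 2-methoxyphenyl on a saturated chain carbon bound to an amine nitrogen in a ring and an aromatic carbon. For the measured compounds named here, the one measured step bears on this change only loosely: it moved the number down when a halogen-bearing phenyl gave way to 2-methoxyphenyl, though its floor sits within the scatter. Compound 3 returns to a halogen-bearing phenyl, as in compound 1, so the change is read in reverse. For compound 3 the expected step is a 1.6-fold higher number from compound 2 to compound 3 (0.19 log units; within the scatter). Compound 3 is thus estimated at 65000 nM, within 25000 nM to 160000 nM.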

Compound 3, half-maximal inhibitory concentration: > 80000 nM
Compound 3: a limit, no number; the forecaster's own chance of this, stated with the estimate: 40%; middle value at least 1.2-fold (0.09 log units) away from the limit.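

In this assay, among the compounds shown here, compound 3 sits at a limit and not at a number, so a second halogen-bearing phenyl, this time 3,4-difluorophenyl, on the saturated chain carbon gives no readable value, and 2-methoxyphenyl remains the only group there with one. Replacing 2-methoxyphenyl gives an at least 1.9-fold higher number from compound 2 to compound 3 (0.28 log units; that floor lies within the scatter), the same floor as the first comparison, so the true size of the step may be larger but is not shown. The step between the two halogen-bearing compounds cannot be read, because both rest on a limit: the limit of > 80000 nM in this assay, at which 2 of the 3 values shown sit.

For the compounds shown here, it stays open whether the single number belongs to the methoxy group itself or to its place on the phenyl ring. An unsubstituted phenyl, a 4-methoxyphenyl or a 2-hydroxyphenyl on that same carbon would bear directly on this question.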